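Swapping the amide arm on the saturated ring

The compounds below may be only part of what the source reports. "The series", "measured", "known", "first", "only" and "open" are said of these compounds alone.

Compound 1, `COc1cc2nc(N3CCC(C(=O)NCC4CC4)CC3)nc(N)c2cc1OC`, in an assay on isolated protein for displacement of a labelled ligand from Adrenergic receptor alpha-1 (Rattus norvegicus) (a higher number here means a weaker inhibitor, a lower number a stronger inhibitor), gives 0.9 nM.
Compound 2, `COc1cc2nc(N3CCC(C(=O)Nc4ccccc4)CC3)nc(N)c2cc1OC`, in this assay gives 0.47 nM.
Compound 3, `CCCCNC(=O)CC1CCN(c2nc(N)c3cc(OC)c(OC)cc3n2)CC1`, is not yet measured.

Among the compounds with values here, compound 2 has the lowest of the two numbers, but its only neighbour is compound 1, and the step of a 1.9-fold lower number from compound 1 to compound 2 (0.28 log units; within the scatter) is within the scatter, so the two compounds cannot be told apart on these data. The move to compound 3 is (butylcarbamoyl)methyl in place of phenylcarbamoyl on a saturated ring carbon. Within the data shown here, the one measured step that bears on it, a 1.9-fold lower number from compound 1 to compound 2 (0.28 log units; within the scatter), exchanged the group on the amide nitrogen and changed little; the new change also swaps that group, from an aromatic ring to a butyl chain, and in addition puts an extra carbon between the ring carbon and the carbonyl, for which no comparison exists. Given that the only related step stayed within the scatter, compound 3 is expected to remain close to compound 2, with at most a small rise in the number, a 2.6-fold higher number from compound 2 to compound 3 (0.41 log units; beyond the scatter). The estimate for compound 3 is 1.2 nM, between 0.4 nM and 4 nM.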

Compound 3, inhibition constant: 1.4 nM
Beside the measured number, compound 3's estimate is 1.2-fold (0.07 log units) below it; measured number inside the range.
By their numbers in this assay, from the lowest: compounds 2, 1 and 3 (each within the scatter of the next, the first and the last beyond it).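

In this assay, within the data shown here, replacing phenylcarbamoyl with (butylcarbamoyl)methyl on this saturated ring carbon gives the first step here that lies beyond the scatter, though it is only modest: a 3.0-fold higher number from compound 2 to compound 3 (0.47 log units; beyond the scatter). Against the (cyclopropylmethyl)carbamoyl group, the same arm shows no change that can be read, with a 1.6-fold higher number from compound 1 to compound 3 (0.19 log units; within the scatter), so an arm with no ring can still give a number close to that of compound 1. No measurement here explains either step.

The butyl chain and the added carbon in the arm enter together, so their separate contributions cannot be told apart. From the compounds shown here alone, a butylcarbamoyl group without the added carbon would separate them, and it remains open how an arm ending in an amine or a carboxylic acid would behave at this position.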